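This account rests on a few compounds, and the source may have more. Where it says the series, first, only, none or still open, it means among the compounds named here.

Working notes on the triazine series.

Compound 1 `Cc1cc(=O)oc2cc(OCc3nc(N)nc(Nc4ccc(Cl)cc4)n3)ccc12` in an assay on COS-7 cells for agonist activity at Free fatty acid receptor 1 (Homo sapiens), read by scintillation counting and inositol phosphate accumulation, with a stated time of 90 min (on this read-out higher numbers stand for an effect only at larger amounts of compound and lower numbers for an effect already at smaller amounts), gives 32500 nM. Compound 2 `Cc1cc(=O)oc2cc(OCc3nc(N)nc(Nc4ccc(Cl)c(Cl)c4)n3)ccc12` carries a second chloro group; the change chloro in place of hydrogen on an aromatic carbon brings a 42-fold lower number from compound 1 to compound 2 (1.62 log units; beyond the scatter), so compound 2 in this assay gives 780 nM. Compound 3 `Cc1ccc(Nc2nc(N)nc(COc3cccc(N4CCCC4=O)c3)n2)cc1Cl` belongs to a different core; the difference between its core and that of compound 1 is not broken down here. In this assay compound 3 gives 820 nM, a value that sits within the scatter of the value of compound 2.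

Compound 4 `Cc1ccc(Nc2nc(N)nc(COc3ccc(Cl)c(N4CCCC4=O)c3)n2)cc1Cl` has not yet been measured. It differs from compound 3 by chloro in place of hydrogen on an aromatic carbon. This is the same kind of change as from compound 1 to compound 2, but not the same: there the entering chloro sat ortho to a chloro group and meta to a large group, here it sits ortho to a 2-oxopyrrolidin-1-yl group and para to a large group. The earlier step was large, yet the surroundings differ, so a smaller step is expected: a 2.7-fold lower number from compound 3 to compound 4 (0.44 log units; beyond the scatter) is the estimate for compound 4 in this assay. Compound 4 is expected to give 300 nM, with a range from 60 nM to 1500 nM.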

Compound 4, half-maximal effective concentration: 2450 nM
Beside the measured number, compound 4's estimate is 8.2-fold (0.91 log units) below it, and the stated range ends below it.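

In this assay chloro in place of hydrogen on an aromatic carbon brings a 3.0-fold higher number from compound 3 to compound 4 (0.48 log units; beyond the scatter), which runs against the direction of the earlier step. The two steps differ in both size and direction, and the gap between them lies beyond the scatter: the same change on two cores in this assay, a 42-fold lower number (1.62 log units; beyond the scatter) from compound 1 to compound 2 and a 3.0-fold higher number (0.48 log units; beyond the scatter) from compound 3 to compound 4, 120-fold (2.10 log units) apart, beyond the scatter of two such steps. For the compounds shown here, the result of this change on one core therefore cannot be carried over to the other, but with only two pairs, which differ both in the core and in the surroundings of the entering chloro, the data cannot show which of these sets the difference.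

The compounds shown leave open whether a fluoro or a methoxy group at the same place, ortho to a 2-oxopyrrolidin-1-yl group, would move the number in the same direction as chloro. Also open, as far as these compounds go, is how the chloro step would run if the 2-oxopyrrolidin-1-yl group gave way to a carboxylic acid or an amine.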